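The source may hold more compounds than are shown below. What is called first, only, known or untested is meant among the compounds shown, and "the series" means these compounds.

In a functional assay on Hs-578T cells (Homo sapiens) for antiproliferative activity (a higher number here means a weaker inhibitor of growth, a lower number a stronger inhibitor of growth), compound 1 (`CCCCCOCCCCCCC/C=C1\CC(CO)(COC(=O)C(C)(C)C)OC1=O`) gives 3 ug/mL and compound 2 (`CC(C)(C)C(=O)OCCCCCCCCCCCCCCC/C=C1\CC(CO)(COC(=O)C(C)(C)C)OC1=O`) gives 5.24 ug/mL, so these two values lie within the usual scatter of each other. The next molecule, compound 3 (`CC(=O)NCCCCCCCCCCCCCCC/C=C1\CC(CO)(COC(=O)C(C)(C)C)OC1=O`), differs from compound 2 in one place: acetamido in place of ((tert-butyl)carbonyl)oxy on a saturated chain carbon, ten or more bonds along the chain from a double-bonded chain carbon. For the measured compounds named here, no measured pair shows what this swap does, so no direction can be argued. In this assay, the expected change is none beyond the scatter, an estimated 1.2-fold lower number from compound 2 to compound 3 (0.07 log units; within the scatter). For compound 3 the estimated value is 4.5 ug/mL, with an expected range from 1.8 ug/mL to 11 ug/mL.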

Compound 3, concentration for 50% growth inhibition: > 10 ug/mL
Compound 3 was reported as a limit; the forecaster's own chance of this, stated with the estimate: 5%; at least 2.2-fold (0.34 log units) between middle value and limit.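

In this assay compound 3 gives > 10 ug/mL, which is a limit of the assay and not a number. Acetamido in place of ((tert-butyl)carbonyl)oxy gives an at least 1.9-fold higher number from compound 2 to compound 3 (0.28 log units; that floor lies within the scatter), while 8-acetamidooctyl in place of pentyloxy gives an at least 3.3-fold higher number from compound 1 to compound 3 (0.52 log units; beyond the scatter), so the chain end now shows a first change beyond the scatter, towards weaker growth inhibition. Both steps are floors, and their true size stays unknown: the limit of > 10 ug/mL in this assay, at which 1 of the 3 values shown sits.

On these data alone, whether a free amine or a carboxylic acid at the chain end would restore growth inhibition remains open. So does the effect of a shorter acetamido chain.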